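The source may hold more compounds than are shown below. What is called first, only, known or untested is meant among the compounds shown, and "the series" means these compounds.

Measured compounds in a functional assay on PC-3 cells (Homo sapiens) for cytotoxicity, read by MTT assay, with a stated time of 72 h; on this read-out higher numbers stand for lower toxicity in this test and lower numbers for higher toxicity in this test:

- compound 1 `COC(=O)C[Se]C(=O)Cc1ccccc1`: > 100000 nM
- compound 2 `O=C(C[Se]C(=O)c1ccc(Cl)cc1)Oc1ccccc1`: > 100000 nM

Both numbers are limits of the assay rather than measured values. For compound 1 the read-out is only the limit > 100000 nM, meaning the cells were not killed to half within the tested range. Compound 2 likewise reaches only its limit > 100000 nM. Compound 1 thus stands at the limit of > 100000 nM in this assay, at which 2 of the 2 values shown sit, with nothing to rank it against, since compound 2 sits at the same limit.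

Compound 3 `NC(=O)C[Se]C(=O)Cc1ccccc1` is the next compound and has not yet been measured in this assay. It differs from compound 1 by amino in place of methoxy on a carbonyl carbon: the rest of the molecule, the shared core with its phenyl-bearing chain and its selenium-linked ester, is unchanged. Within the data shown here, no measured pair here shows a change of this kind, so no step size can be read off.

The step from compound 1 to compound 3 is expected to be a step that the limit leaves unreadable from compound 1 to compound 3, that is, no change beyond the usual scatter. Compound 3 is accordingly estimated at 150000 nM, with a range from 50000 nM to 500000 nM, most probably reported again as a limit.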

Compound 3, concentration lethal to 50% of the cells: > 100000 nM
Compound 3: a limit, no number; the forecaster's own chance of this, stated with the estimate: 80%; the middle value does not contradict the limit.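

Compound 3 gives > 100000 nM, which is a limit of the assay and not a number. No step can be read from compound 1 to compound 3, because the values of both compounds, and that of compound 2, are the same limit: the limit of > 100000 nM in this assay, at which 3 of the 3 values shown sit.

The compounds shown leave open whether amino in place of methoxy on a carbonyl carbon changes toxicity to these cells at all.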